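Quinoline Ether Amides: From Fluorodimethylphenyl to Pyrimidinyl

A few compounds are considered here, and "the series" means these few. Any claim that something is new, unique, unknown or untested is made for them only; others in the source may bear on it.

The series shares one core, seen in compound 1 `COc1cccc(NC(=O)COc2cc(C)nc3ccc(OC)cc23)c1`, compound 2 `COc1ccc2nc(C)cc(OCC(=O)Nc3cc(C)c(OC)c(C)c3)c2c1` and compound 3 `COc1ccc2nc(C)cc(OCC(=O)Nc3cc(C)c(F)c(C)c3)c2c1`, and differs only in the group on the amide nitrogen. In a physicochemical assay for lipophilicity, read by HPLC, in phosphate buffer, measured as chromatographic lipophilicity, at pH 7.4 (a higher number here means a more lipophilic compound, a lower number a more polar compound), compound 1 gives 4.49, compound 2 gives 4.99 and compound 3 gives 5.5. Compound 3 stands highest of the three: the step of a number 1.01 log units higher from compound 1 to compound 3 (beyond the scatter) and the step of a number 0.51 log units higher from compound 2 to compound 3 (beyond the scatter) both end at it, so its two neighbours lie clearly below.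

Compound 4 `COc1ccc2nc(C)cc(OCC(=O)Nc3ccncn3)c2c1` is the next member and has not yet been measured in this assay. It differs from compound 3 in one place: pyrimidin-4-yl in place of 4-fluoro-3,5-dimethylphenyl on an amide-type nitrogen. Neither measured step is an exact match for this change. The nearer guide is a number 0.51 log units higher from compound 2 to compound 3 (beyond the scatter), where an oxygen-bearing substituent gave way to fluorine on the same ring; compound 4 goes the other way and by more, losing the whole fluorodimethyl ring and gaining a ring that carries two nitrogens. A step downward well beyond the scatter is therefore expected, and it is expected to exceed the size of a number 1.01 log units higher from compound 1 to compound 3 (beyond the scatter).

Compound 4 is estimated at 3, within a range of 2.3 to 3.7, an expected step of a number 2.50 log units lower from compound 3 to compound 4 (beyond the scatter).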

Compound 4, distribution coefficient: 2.53
Estimate against measurement, compound 4: 0.47 log units above, and the stated range covers the measured number.
By their numbers in this assay, from the lowest: compound 4; then compound 1; then compound 2; then compound 3.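

In this assay, the exchange of 4-fluoro-3,5-dimethylphenyl for pyrimidin-4-yl on the amide-type nitrogen gives a step of a number 2.97 log units lower from compound 3 to compound 4 (beyond the scatter), and the exchange of 3-methoxyphenyl for the same group gives a number 1.96 log units lower from compound 1 to compound 4 (beyond the scatter). Compounds 1, 2 and 3 all carry a substituted phenyl at this position, so their steps show only what changes when the substituents on a carbon-only ring change, whereas compound 4 shows that replacing the ring itself with one bearing hetero atoms moves the number much further, taking it well below that of compound 1, the lowest of those three. Nothing measured here accounts for the size of these steps.

The compounds shown leave open how much of the fall belongs to the ring nitrogens and how much to the loss of the fluoro, methyl or methoxy substituents, a question that an unsubstituted phenyl or a pyridinyl on the same nitrogen would help to separate. They also leave open whether a methyl group or an amine placed on the pyrimidin-4-yl ring would recover part of the lost ground in this assay.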